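Fluoro for chloro: from compound 2 to compound 3

This account rests on a few compounds, and the source may have more. Where it says the series, first, only, none or still open, it means among the compounds named here.

Measured compounds:
compound 1, `NCCCCCOC[C@H]1O[C@@H](OCCc2c[nH]c3ccccc23)[C@H](OCc2ccccc2)[C@@H](OCc2ccccc2)[C@@H]1OCc1cccnc1`: 360 nM
compound 2, `NCCCCCOC[C@H]1O[C@@H](OCCc2c[nH]c3ccccc23)[C@H](OCc2ccccc2)[C@@H](OCc2ccccc2)[C@@H]1OCc1ccc(Cl)nc1`: 1200 nM

In an assay on isolated protein for binding affinity to somatostatin receptor type 4 (Homo sapiens), read by radioligand binding (a higher number here means a weaker inhibitor, a lower number a stronger inhibitor), compound 1 gives 360 nM, while compound 2 gives 1200 nM. Compound 2 stands highest of the two numbers; its nearest neighbour is compound 1, and the step of a 3.3-fold higher number from compound 1 to compound 2 (0.52 log units; beyond the scatter) lies beyond the scatter.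

Compound 3, `NCCCCCOC[C@H]1O[C@@H](OCCc2c[nH]c3ccccc23)[C@H](OCc2ccccc2)[C@@H](OCc2ccccc2)[C@@H]1OCc1ccc(F)nc1`, differs from compound 2 by fluoro in place of chloro on an aromatic carbon. Among the measured compounds shown here, no measured pair covers this swap directly. For the measured compounds named here, the only step that bears on it is a 3.3-fold higher number from compound 1 to compound 2 (0.52 log units; beyond the scatter), which places the chloro compound 2 above the unsubstituted compound 1. Fluoro at the same aromatic carbon is therefore expected to land between those two numbers, a modest step downward of uncertain size. The estimated step is a 1.8-fold lower number from compound 2 to compound 3 (0.27 log units; within the scatter). For compound 3 the expected value in this assay is 650 nM, with a range from 280 nM to 1500 nM.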

Compound 3, inhibition constant: 680 nM
Estimate against measurement, compound 3: 1.0-fold (0.02 log units) below, within the range that was stated.
By their numbers in this assay, from the lowest: compounds 1, 3 and 2 (each within the scatter of the next, the first and the last beyond it).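

In this assay, fluoro in place of chloro on the aromatic carbon next to the ring nitrogen gives a 1.8-fold lower number from compound 2 to compound 3 (0.25 log units; within the scatter), so the two halogens are not separated at this position. Fluoro in place of hydrogen at the same carbon gives a 1.9-fold higher number from compound 1 to compound 3 (0.28 log units; within the scatter), whereas chloro in place of hydrogen gives a 3.3-fold higher number from compound 1 to compound 2 (0.52 log units; beyond the scatter); of the three compounds, only compound 1 and compound 2 stand apart, and compound 3 cannot be told from either. No measurement is available that would explain these steps.

Open, on these data alone, is whether methoxy, an amine or trifluoromethyl on this carbon would read like hydrogen, like chloro or differently from both. Also open, as far as these compounds go, is whether these steps would hold with a longer amine chain on the shared core.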